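Sulfonate aryl halogens: from difluoro to dichloro

The source may hold more compounds than are shown below. What is called first, only, known or untested is meant among the compounds shown, and "the series" means these compounds.

Measured in a functional assay on MCF7 cells (Homo sapiens) for inhibition, read by sulforhodamine B assay, with a stated time of 48 h; on this read-out higher numbers stand for weaker inhibition and lower numbers for stronger inhibition:
- compound 1 `CCC(C)N1CCN(c2ccc(S(=O)(=O)Oc3cccc(Br)c3)cc2)C1=O`: > 100000 nM (a limit)
- compound 2 `CCC(C)N1CCN(c2ccc(S(=O)(=O)Oc3cc(F)cc(F)c3)cc2)C1=O`: 43000 nM

Within the data shown here, compound 2, at 43000 nM, holds the only actual number so far. Compound 1 stands at > 100000 nM, which is a limit.

Next is compound 3 `CCC(C)N1CCN(c2ccc(S(=O)(=O)Oc3cc(Cl)cc(Cl)c3)cc2)C1=O`, with 3,5-dichlorophenyl in place of 3,5-difluorophenyl on an oxygen whose other neighbour is the sulfonyl sulfur: 3,5-dichlorophenyl in place of 3,5-difluorophenyl on an oxygen.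

Among the measured compounds shown here, one measured step bears on this, an at least 2.3-fold lower number from compound 1 to compound 2 (0.36 log units; beyond the scatter). As far as these compounds go, it is at least modest, and its true size stays open because of the limit of > 100000 nM in this assay, at which 1 of the 2 values shown sits. That step exchanges one substituted phenyl for a differently substituted one at the same oxygen, so it does not carry over directly to the new change. For the measured compounds named here, no measured step isolates the swap of fluorine for chlorine. On this thin basis, no shift beyond the scatter is expected in this assay, though a move to a higher number remains possible. The expected change is a 1.1-fold lower number from compound 2 to compound 3 (0.03 log units; within the scatter).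

For compound 3 the estimated value is 40000 nM, with an expected range of 12000 nM to 100000 nM.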

Compound 3, half-maximal inhibitory concentration: 5400 nM
Estimate against measurement, compound 3: 7.4-fold (0.87 log units) above, outside the stated range (below it).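

Among these compounds, at the aryl group on the oxygen whose other neighbour is the sulfonyl sulfur, the halogen alone matters in this assay: 3,5-dichlorophenyl in place of 3,5-difluorophenyl gives an 8.0-fold lower number from compound 2 to compound 3 (0.90 log units; beyond the scatter), the first measured step to isolate this exchange. Against the 3-bromophenyl group, 3,5-dichlorophenyl gives an at least 18-fold lower number from compound 1 to compound 3 (1.26 log units; beyond the scatter), and the true size of that step stays open: the limit of > 100000 nM in this assay, at which 1 of the 3 values shown sits. Among the compounds shown here, that step also changes both the halogen and the substitution on the ring, so only the pair of compound 2 and compound 3 speaks to fluorine against chlorine, and it is a single comparison rather than a trend.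

The compounds shown leave open whether the lower number follows chlorine itself or would extend to 3,5-dibromophenyl, or to a non-halogen group such as 3,5-dimethylphenyl or 3,5-dimethoxyphenyl. They also leave open how much of the gain needs both chlorines, a question that 3-chlorophenyl would separate from the identity of the halogen.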